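The source may hold more compounds than are shown below. What is called first, only, known or untested is meant among the compounds shown, and "the series" means these compounds.

In an ADME assay on HepG2 cells (Homo sapiens) for cytotoxicity (a higher number here means that more compound is tolerated, a lower number that less compound is tolerated), compound 2 `Fc1cccc(COc2ccc(Nc3ncnc4cc(C#CCN5CCNCC5)sc34)cc2Cl)c1` gives > 29 uM, which is a limit of the assay and not a number. Compound 1 `CCOC(=O)CN(C)CC#Cc1cc2ncnc(Nc3ccc(OCc4cccc(F)c4)c(Cl)c3)c2s1` gives 26 uM. Compound 3 `Fc1cccc(COc2ccc(Nc3ncnc4cc(C#CCN5CCCC5)sc34)cc2Cl)c1` has not been measured yet. It carries pyrrolidin-1-yl in place of piperazin-1-yl on a saturated chain carbon bound to a triple-bonded carbon. For the measured compounds named here, the only measured step that bears on this change sits at the same place: an at least 1.1-fold higher number from compound 1 to compound 2 (0.04 log units; that floor lies within the scatter), where piperazin-1-yl replaces ((ethoxycarbonyl)methyl)(methyl)amino. That single step gives no sign that changes at this place move tolerance beyond the scatter, and it rests on a limit. No step beyond the scatter, in either direction, is therefore expected in this assay. The estimated step is an at least 1.0-fold lower number from compound 2 to compound 3 (0.03 log units; that floor lies within the scatter). For compound 3 the expected value is 27 uM, with an estimated range of 12 uM to 50 uM.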

Compound 3, half-maximal toxic concentration: 4.9 uM
Beside the measured number, compound 3's estimate is 5.5-fold (0.74 log units) above it; the measured number lies below the stated range.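

In this assay, the place on a saturated chain carbon bound to a triple-bonded carbon now proves able to change how much compound is tolerated: the earlier step there stayed within the scatter, but pyrrolidin-1-yl in place of piperazin-1-yl gives an at least 5.9-fold lower number from compound 2 to compound 3 (0.77 log units; beyond the scatter). Compound 2 stands at a limit of the assay and not at a number, so the size of this step is only a floor: the limit of > 29 uM in this assay, at which 1 of the 3 values shown sits. The change does not rest on that limit alone, as pyrrolidin-1-yl in place of ((ethoxycarbonyl)methyl)(methyl)amino gives a 5.3-fold lower number from compound 1 to compound 3 (0.72 log units; beyond the scatter).

Pyrrolidin-1-yl and piperazin-1-yl differ at once in ring size, ring nitrogens and hydrogen-bond donors, and the compounds shown cannot tell which difference matters. A piperidin-1-yl group here would pair the six-membered ring with the single ring nitrogen of pyrrolidin-1-yl and help separate the first two.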